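The source may report more compounds than this note shows. Statements on the series, on what has been measured and on what is new or still open speak of the compounds shown alone.

Measured in a toxicity assay on THP-1 cells (Homo sapiens) for inhibition; a lower number here means that less compound is tolerated, a higher number that more compound is tolerated:
Compound 1 `COc1ccc(-c2cnc(NC(=O)c3ncc[nH]3)n2C)cc1`: > 100000 nM, a limit
Compound 2 `Cn1c(-c2ccc(C#N)cc2)cnc1NC(=O)c1ccc(F)cc1`: > 50000 nM, a limit
Compound 3 `Cn1c(-c2ccc(Cl)cc2)cnc1NC(=O)c1ncc[nH]1`: 52000 nM

Compound 3 is the only one of the three with an actual number, since the other two values are limits of the assay. The next compound is compound 4 `Cn1c(-c2ccc(C#N)cc2)cnc1NC(=O)c1ncc[nH]1`. It has cyano in place of chloro on an aromatic carbon, on a six-membered aromatic ring of carbon only, para to a large group: cyano in place of chloro on an aromatic carbon.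

Among the compounds with values here, one measured step bears on this place, chloro in place of methoxy on an aromatic carbon: an at least 1.9-fold lower number from compound 1 to compound 3 (0.28 log units; that floor lies within the scatter). On these data alone, its true size is unknown, as only a floor can be given. Compound 2 also carries cyano but differs elsewhere, and it gives > 50000 nM, again a limit.

The step from compound 1 gives no ground for expecting a move beyond the scatter in either direction in this assay. The expected change is a 1.2-fold higher number from compound 3 to compound 4 (0.06 log units; within the scatter). Compound 4 is estimated at 60000 nM, with an expected range from 28000 nM to 130000 nM.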

Compound 4, half-maximal cytotoxic concentration: > 100000 nM
Compound 4 gave a limit, no number (the forecaster's own chance of this, stated with the estimate: 55%); middle value at least 1.6-fold (0.22 log units) away from the limit.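

In this assay, cyano in place of chloro on this aromatic carbon, para to a large group, gives an at least 1.9-fold higher number from compound 3 to compound 4 (0.28 log units; that floor lies within the scatter). Only a floor is known for this step, so it cannot be said to go beyond the usual scatter. Of the four compounds, compound 3 alone has an actual number, while compound 4 with cyano sits at a limit, like compound 1 with methoxy: the limit of > 100000 nM in this assay, at which 2 of the 4 values shown sit.

The steps to compound 4 from compound 1 and from compound 2 cannot be read: both ends of each are limits. On these data alone, the true size of the change from chloro to cyano stays open, as does whether an amine or a carboxylic acid on this carbon would give a number in this assay rather than a limit.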